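The compounds below may be only part of what the source reports. "The series", "measured", "known", "first", "only" and "open" are said of these compounds alone.

Measured in an ADME assay on HEK293 cells (Homo sapiens) for cytotoxicity, read by MTT assay, with a stated time of 48 h; a higher number here means a weaker inhibitor, a lower number a stronger inhibitor:
compound 1 `CN(C)CCn1c(N)c(-c2nc3ccccc3[nH]2)c2nc(C#N)c(C#N)nc21`: 9730 nM
compound 2 `CCN(CC)CCn1c(N)c(-c2nc3ccccc3[nH]2)c2nc(C#N)c(C#N)nc21`: 12200 nM
compound 3 `CCCn1c(N)c(-c2nc3ccccc3[nH]2)c2nc(C#N)c(C#N)nc21`: > 50000 nM (a limit, not a number)

Compound 3 has only a limit in this assay, which is > 50000 nM.

The next structure is compound 4 `CCN(CC)CCCCn1c(N)c(-c2nc3ccccc3[nH]2)c2nc(C#N)c(C#N)nc21`. The change is (diethylamino)methyl in place of hydrogen on a saturated chain carbon, three bonds along the chain from an aromatic nitrogen. Cut one bond further out, this reads propyl to 4-(diethylamino)butyl.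

The closest measured steps are an at least 4.0-fold higher number from compound 2 to compound 3 (0.61 log units; beyond the scatter) and an at least 5.1-fold higher number from compound 1 to compound 3 (0.71 log units; beyond the scatter), both beyond the scatter. By contrast, a 1.3-fold higher number from compound 1 to compound 2 (0.10 log units; within the scatter) lies within it. Going by the values given here, compound 4 carries the diethylamino group of compound 2 on a longer chain, and no measured step covers that chain length. A step towards lower numbers is therefore expected, opposite in direction to an at least 4.0-fold higher number from compound 2 to compound 3 (0.61 log units; beyond the scatter), and its size is bounded only loosely. The expected change is an at least 5.5-fold lower number from compound 3 to compound 4 (0.74 log units; beyond the scatter). Compound 4 is estimated at 9000 nM, with an expected range of 3000 nM to 30000 nM.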

Compound 4, half-maximal inhibitory concentration: 5370 nM
Compound 4: middle estimate off by 1.7-fold (0.22 log units), on the high side; low and high end bracket the measured number.
By their numbers in this assay, from the lowest: compounds 4, 1 and 2 (each within the scatter of the next, the first and the last beyond it). At a limit, above all of these: compound 3.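

In this assay, going from propyl to 4-(diethylamino)butyl gives an at least 9.3-fold lower number from compound 3 to compound 4 (0.96 log units; beyond the scatter), so the drop seen with the two shorter amine chains also holds on this longer chain, though compound 3 has only a limit and the step has no upper bound: the limit of > 50000 nM in this assay, at which 1 of the 4 values shown sits.

With the diethylamino group held constant, the longer chain gives a 2.3-fold lower number from compound 2 to compound 4 (0.36 log units; beyond the scatter), the first sign in the series that chain length alone moves the number. Against the dimethylamino chain, a 1.8-fold lower number from compound 1 to compound 4 (0.26 log units; within the scatter) does not separate the two compounds.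

Whether the number changes steadily with chain length remains open, since 3-(diethylamino)propyl and any longer chain lie outside the compounds shown. Also open, on these data alone, is how a ring amine such as piperidine or morpholine, or a hydroxyl group at the chain end, would compare on the butyl chain.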